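A few compounds are considered here, and "the series" means these few. Any claim that something is new, unique, unknown or untested is made for them only; others in the source may bear on it.

Measured so far in a functional assay on the whole organism (blood, strain Wistar-Okamoto) with Rattus norvegicus as the target, with a stated time of 5 days; a lower number here means that less compound is needed, a higher number that more compound is needed for the effect:
compound 1 `CC(C)/N=C(\NC#N)Nc1cccnc1` — 2.5 mg/kg
compound 2 `CC(C)(C)CC(C)(C)/N=C(\NC#N)Nc1cccnc1` — 50 mg/kg

Compound 1 gives the lowest of the two numbers in this assay; the nearest is compound 2, reached by a 20-fold higher number from compound 1 to compound 2 (1.30 log units; beyond the scatter). Among the measured compounds shown here, that step, neopentyl in place of hydrogen on a saturated chain carbon bound to a double-bonded nitrogen and two saturated chain carbons, is the only measured change and it enlarges the group on the double-bonded nitrogen.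

Compound 3 `N#CN/C(=N\CC1CCCO1)Nc1cccnc1` is not yet measured. It differs from compound 1 by (oxolan-2-yl)methyl in place of isopropyl on a double-bonded nitrogen. The step from compound 1 to compound 2 bears on it, since both changes add atoms to the group on the double-bonded nitrogen; the group entering here carries fewer added atoms than neopentyl, so a higher number is expected, but a smaller step. For compound 3 the expected step is a 2.4-fold higher number from compound 1 to compound 3 (0.38 log units; beyond the scatter). Compound 3 is estimated at 6 mg/kg, in the range 2 mg/kg to 20 mg/kg.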

Compound 3, minimum effective dose: 50 mg/kg
Estimate against measurement, compound 3: 8.3-fold (0.92 log units) below, outside the stated range (above it).
By their numbers in this assay, from the lowest: compound 1; then compounds 2 and 3 (each within the scatter of the next).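

In this assay, (oxolan-2-yl)methyl in place of isopropyl on a double-bonded nitrogen gives a 20-fold higher number from compound 1 to compound 3 (1.30 log units; beyond the scatter), so a large step at this position is not confined to the branched chain of compound 2. Compound 2 stands at 50 mg/kg and compound 3 at 50 mg/kg, so an open chain and a group carrying a five-membered non-aromatic ring with an oxygen give the same printed value. No available evidence bears on what lies behind this step.

The shown compounds do not separate the effects of the ring, its oxygen and the added atoms; a cyclopentylmethyl group would isolate the oxygen. Going by these compounds, whether a group smaller than isopropyl, such as methyl or ethyl, lowers or raises the number remains open.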